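The compounds below may be only part of what the source reports. "The series", "measured", "known", "first", "only" and "open" are said of these compounds alone.

Working notes on the series.

The series is tested in a functional assay on U-373MG ATCC cells (Homo sapiens) for cytotoxicity, read by MTT assay, with a stated time of 72 h; on this read-out higher numbers stand for weaker inhibition and lower numbers for stronger inhibition. Going by the values given here, compound 1 `Cc1ccc2[nH]c(-c3ccc[nH]3)c(C3CC(=O)NC3=O)c2c1` gives 5000 nM in this assay, and it is the only compound in the set with a number rather than a limit. Compound 2 `Cc1ccc2[nH]c(-n3cccn3)cc2c1` returns only a limit, > 100000 nM, in this assay. Compound 3 `O=C1NC(=O)c2c1c1c3cc(O)ccc3[nH]c1c1cccn21` likewise returns a limit, > 100000 nM, in this assay. Among the compounds with values here, both limits are the limit of > 100000 nM in this assay, at which 2 of the 3 values shown sit, so compound 1 is the sole anchor for any comparison.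

Compound 4 `O=C1CC(c2c(-c3ccc[nH]3)[nH]c3ccccc23)C(=O)N1` has not yet been measured in this assay. It differs from compound 1 by hydrogen in place of methyl on an aromatic carbon. Within the data shown here, no pair of measured compounds in the set differs in a single place, so there is no measured step to draw on; the change is small, and it is expected to move potency by no more than the scatter of repeated measurements, with at most a slight weakening. The estimated step is a 1.4-fold higher number from compound 1 to compound 4 (0.15 log units; within the scatter), and for compound 4 the expected value in this assay is 7000 nM, within 2500 nM to 20000 nM.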

Compound 4, half-maximal inhibitory concentration: 4000 nM
Compound 4: the middle estimate sits 1.8-fold (0.24 log units) above what was measured, within the range that was stated.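

Going by these compounds alone, this is the first single-place step: in this assay, hydrogen in place of methyl on this aromatic carbon gives a 1.3-fold lower number from compound 1 to compound 4 (0.10 log units; within the scatter). The methyl group is therefore not required for the cytotoxic activity of compound 1 at this position, and its removal leaves activity unchanged within the scatter, although one pair shows this for the shared core alone. Nothing measured in the set accounts for this result.

Whether this aromatic carbon accepts groups other than methyl and hydrogen stays open, for example a methoxy group, an amine or a carboxylic acid, as none of these appears among the compounds shown. Also open, as far as these compounds go, is whether other positions on the six-membered aromatic ring respond to substitution in the same way.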